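Branching at the Indole Nitrogen Substituent and Reductase Inhibition

The source may report more compounds than this note shows. Statements on the series, on what has been measured and on what is new or still open speak of the compounds shown alone.

Compound 1, `CCC(C)n1ccc2cc(/C(C)=C/C(=O)Nc3ccccc3OCCCC(=O)O)ccc21`: 67 nM
Compound 2, `C/C(=C\C(=O)Nc1ccccc1OCCCC(=O)O)c1ccc2c(ccn2C(C(C)C)C(C)C)c1`: 14 nM
Compound 3, `C/C(=C\C(=O)Nc1ccccc1OCCCC(=O)O)c1ccc2c(ccn2Cc2cccc(C)c2)c1`: 250 nM

In an assay on Prostate gland for inhibition of steroid 5-alpha-reductase (Rattus norvegicus) (a lower number here means a stronger inhibitor, a higher number a weaker inhibitor), compound 3 has the highest number of the three. The step of a 3.7-fold higher number from compound 1 to compound 3 (0.57 log units; beyond the scatter) and the step of an 18-fold higher number from compound 2 to compound 3 (1.25 log units; beyond the scatter) both show that a 3-methylbenzyl on the aromatic nitrogen gives a weaker inhibitor than a branched alkyl group there. Compound 4, `CCC(c1ccccc1)n1ccc2cc(/C(C)=C/C(=O)Nc3ccccc3OCCCC(=O)O)ccc21`, carries the change (1-phenylpropyl in place of 3-methylbenzyl on an aromatic nitrogen), so the group on the aromatic nitrogen keeps its phenyl ring but is now branched at the carbon joined to that nitrogen, as in the sec-butyl of compound 1. Within the data shown here, no measured step covers this exact change. A modest lowering of the number is expected, a 2.8-fold lower number from compound 3 to compound 4 (0.44 log units; beyond the scatter), and compound 4 is estimated at 90 nM with a range from 30 nM to 270 nM.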

Compound 4, half-maximal inhibitory concentration: 19 nM
The estimate for compound 4 lay 4.7-fold (0.68 log units) above the measured number; measured number below the stated range.
By their numbers in this assay, from the lowest: compounds 2 and 4 (each within the scatter of the next); then compound 1; then compound 3.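

In this assay the step to the branched group that keeps its phenyl ring is a 13-fold lower number from compound 3 to compound 4 (1.12 log units; beyond the scatter) and is large, so an aromatic ring on this nitrogen need not give a weak inhibitor. Phenyl on the branching carbon gives a 3.5-fold lower number from compound 1 to compound 4 (0.55 log units; beyond the scatter) and, against the larger branched alkyl group, a 1.4-fold higher number from compound 2 to compound 4 (0.13 log units; within the scatter) so the two groups cannot be told apart here.

Compound 3 also carries a ring methyl that compound 4 lacks, so branching and that methyl are not separated. A plain benzyl or a 1-phenylethyl group would separate them. Nothing given here explains these steps.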